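Methyl to tert-butyl on the urea aryl ring of compound 1

The source may hold more compounds than are shown below. What is called first, only, known or untested is meant among the compounds shown, and "the series" means these compounds.

Compound 1 `Cc1ccc(NC(=O)Nc2cccc(CNc3nccnc3Cl)c2)cc1` gives 9820 nM in a functional assay on T-24 cells (Homo sapiens) for antiproliferative activity, read by MTT assay, with a stated time of 48 h (on this read-out lower numbers stand for stronger inhibition and higher numbers for weaker inhibition), the highest of the two numbers shown. Compound 2 `Cc1ccc(NC(=O)Nc2cccc(CNc3nccnc3Cl)c2)cc1Cl` gives 7390 nM, and a 1.3-fold lower number from compound 1 to compound 2 (0.12 log units; within the scatter). Compound 3 `O=C(Nc1cccc(CNc2nccnc2Cl)c1)NC1CCCCC1` reaches only a limit, > 40000 nM. That gives an at least 4.0-fold higher number from compound 1 to compound 3 (0.60 log units; beyond the scatter) and an at least 5.4-fold higher number from compound 2 to compound 3 (0.73 log units; beyond the scatter). Compound 4 `CC(C)(C)c1ccc(NC(=O)Nc2cccc(CNc3nccnc3Cl)c2)cc1` differs from compound 1 by tert-butyl in place of methyl on an aromatic carbon. Among the measured compounds shown here, none of the measured steps touches this position: the two larger steps replace the whole aryl group on the urea nitrogen, and the one step within the scatter changes a different ring carbon. The step is therefore expected to stay within the scatter, a 1.4-fold lower number from compound 1 to compound 4 (0.15 log units; within the scatter). Compound 4 is estimated at 7000 nM, between 2500 nM and 20000 nM.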

Compound 4, half-maximal inhibitory concentration: 6010 nM
Beside the measured number, compound 4's estimate is 1.2-fold (0.07 log units) above it; the range from low to high includes it.
By their numbers in this assay, from the lowest: compounds 4, 2 and 1 (each within the scatter of the next). At a limit, above all of these: compound 3.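

Replacing methyl (1 heavy atom) with tert-butyl (4 heavy atoms) gives a 1.6-fold lower number from compound 1 to compound 4 (0.21 log units; within the scatter) in this assay. Among the compounds shown here, this aromatic carbon, para to a large group, therefore carries the larger tert-butyl group with no change beyond the scatter, something the earlier compounds, which differ elsewhere, did not show. Nothing given here explains this outcome. The compounds shown leave open whether a different kind of group on this carbon, such as an amine or a carboxylic acid, would also stay within the scatter of compound 1.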